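This account rests on a few compounds, and the source may have more. Where it says the series, first, only, none or still open, it means among the compounds named here.

Two related compounds have been tested in a functional assay on IGROV-1 cells (Homo sapiens) for cytotoxicity, read by sulforhodamine B assay, with a stated time of 48 h; a lower number here means a stronger inhibitor of growth, a higher number a weaker inhibitor of growth. Compound 1 `ClCc1ccc(Cn2cnc3c(Cl)ncnc32)cc1` gives 3160 nM. Compound 2 `ClCc1ccccc1Cn1cnc2c(Cl)nc(Cl)nc21` gives 1540 nM, which is the lower of the two numbers; the gap to compound 1 lies beyond the usual scatter, so compound 2 counts as the stronger inhibitor of growth of the pair. Compound 3 `ClCc1ccccc1Cn1cnc2c(Cl)ncnc21` has not yet been tested in this assay. It is compound 2 with one change: hydrogen in place of chloro on an aromatic carbon. Among the compounds with values here, no measured pair shows this exact change, so its effect can only be guessed. Compound 3 is expected to be a somewhat weaker inhibitor than compound 2, by a step of a 1.6-fold higher number from compound 2 to compound 3 (0.21 log units; within the scatter) that may not rise beyond the scatter. The estimate for compound 3 in this assay is 2500 nM, with a range from 1000 nM to 6500 nM.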

Compound 3, concentration for 50% growth inhibition: 3160 nM
The estimate for compound 3 lay 1.3-fold (0.10 log units) below the measured number, within the range that was stated.
By their numbers in this assay, from the lowest: compound 2; then compounds 1 and 3 (each within the scatter of the next).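

Within the data shown here, this pair gives the first direct reading of the chloro group on the aromatic carbon between two ring nitrogen atoms. In this assay, putting hydrogen in place of that chloro gives a 2.1-fold higher number from compound 2 to compound 3 (0.31 log units; beyond the scatter), so with the rest of the molecule unchanged, the chloro goes with stronger growth inhibition, although the step is modest and rests on a single pair. Nothing measured here explains why the number moves.

The compounds shown carry only chloro or hydrogen at this position, so it remains open how an amine, a methoxy group or a fluoro group there would compare. Also open, as far as these compounds go, is whether adding chloro at the same position of compound 1 would shift its number by a similar step.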